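This account rests on a few compounds, and the source may have more. Where it says the series, first, only, none or still open, it means among the compounds named here.

Measured so far:
- compound 1 `N#Cc1ccc(N2CCN([C@@H]3CN[C@H](C(=O)N4CCSC4)C3)CC2)cc1`: 4.7 nM
- compound 2 `O=C([C@@H]1C[C@H](N2CCN(c3ccncc3)CC2)CN1)N1CCSC1`: 3.9 nM

Among the compounds with values here, compound 2 holds the lowest of the two numbers in an assay on a cell-free system (plasma) for inhibition of Dipeptidyl peptidase 4 (Rattus norvegicus), read by fluorescence (a lower number here means a stronger inhibitor, a higher number a weaker inhibitor), but its only neighbour, compound 1, sits just a 1.2-fold lower number from compound 1 to compound 2 (0.08 log units; within the scatter) away, so the two cannot be ordered on these data.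

Compound 3 `O=C([C@@H]1C[C@H](N2CCN(c3ccc(Cl)cc3)CC2)CN1)N1CCSC1` is the next member and has not yet been measured. Relative to compound 2 the change is 4-chlorophenyl in place of pyridin-4-yl on an amine nitrogen in a ring. Within the data shown here, the one measured step that bears on this position is the exchange of the aryl group on the same ring nitrogen, from compound 1 to compound 2, which stayed within the scatter. A second exchange of the aryl group at that nitrogen is therefore expected to move the number little, if at all, in either direction, with the expected step being a 1.3-fold higher number from compound 2 to compound 3 (0.11 log units; within the scatter).

Compound 3 is thus estimated at 5 nM, with an expected range from 2 nM to 14 nM.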

Compound 3, half-maximal inhibitory concentration: 10.3 nM
Beside the measured number, compound 3's estimate is 2.1-fold (0.31 log units) below it, and the stated range covers the measured number.
By their numbers in this assay, from the lowest: compounds 2 and 1 (each within the scatter of the next); then compound 3.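

In this assay the aryl group on the amine nitrogen in the ring is not freely interchangeable: 4-chlorophenyl in place of pyridin-4-yl gives a 2.6-fold higher number from compound 2 to compound 3 (0.42 log units; beyond the scatter) and so moves beyond the scatter, unlike the earlier exchange of 4-cyanophenyl for pyridin-4-yl. Chloro in place of cyano on an aromatic carbon gives a 2.2-fold higher number from compound 1 to compound 3 (0.34 log units; beyond the scatter) and shows that a single substituent on this aryl group can also shift the number modestly. Nothing available here accounts for either step.

Three compounds do not show which feature of the aryl group sets the number. As far as these compounds go, whether unsubstituted phenyl, a methoxy or fluoro group on the aromatic carbon, or a cyclohexyl group on that nitrogen would fall with compound 3 or nearer compound 2 remains open.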